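The source may hold more compounds than are shown below. What is called first, only, known or untested is meant among the compounds shown, and "the series" means these compounds.

Compound 3 `CCOC(=O)c1cn(C[C@H]2O[C@@H](n3cc(C)c(=O)[nH]c3=O)[C@H](SCC)[C@@H]2SCC)nn1` stands at the upper edge of what has been seen in this series. In a functional assay on A549 cells (Homo sapiens) for cytotoxicity, read by MTT assay, with a stated time of 72 h (a lower number here means that less compound is needed, a higher number that more compound is needed for the effect), compound 3 gives >= 100000 nM, which is a limit of the assay and not a number. Compound 1 `CCS[C@@H]1[C@H](SCC)[C@@H](Cn2cc(-c3ccc(F)cc3)nn2)O[C@H]1n1cc(C)c(=O)[nH]c1=O` sits at the same limit; in this assay compound 1 gives >= 100000 nM. Going by the values given here, compound 2 `CCS[C@@H]1[C@H](SCC)[C@@H](Cn2cc(-c3ccc(C)cc3)nn2)O[C@H]1n1cc(C)c(=O)[nH]c1=O` is the only member with a read number, and in this assay compound 2 gives 12300 nM. Of the measured steps, an at least 8.1-fold lower number from compound 1 to compound 2 (0.91 log units; beyond the scatter) and an at least 8.1-fold higher number from compound 2 to compound 3 (0.91 log units; beyond the scatter) are both beyond the scatter, whereas a step that the two limits leave unreadable from compound 1 to compound 3 cannot be read because both of its ends sit at the limit of >= 100000 nM in this assay, at which 2 of the 3 values shown sit. Compound 4 `CCS[C@@H]1[C@H](SCC)[C@@H](Cn2cc(-c3cccs3)nn2)O[C@H]1n1cc(C)c(=O)[nH]c1=O` differs from compound 3 by thiophen-2-yl in place of ethoxycarbonyl on an aromatic carbon. Among the compounds with values here, the step that bears on this change is an at least 8.1-fold higher number from compound 2 to compound 3 (0.91 log units; beyond the scatter), which ran from an aromatic ring to the ester; the incoming group is again an aromatic ring, and the two aryl analogues, compound 1 and compound 2, span the range from the limit down to the one read number. For compound 4 a modest move toward lower numbers in this assay is expected, around 30000 nM, from 8000 nM to 100000 nM. The expected step is an at least 3.3-fold lower number from compound 3 to compound 4 (0.52 log units; beyond the scatter), with a real chance that only the limit is returned once more.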

Compound 4, half-maximal effective concentration: 37300 nM
Beside the measured number, compound 4's estimate is 1.2-fold (0.09 log units) below it; the range from low to high includes it.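

With thiophen-2-yl on this aromatic carbon, the series gains a second read number in this assay: an at least 2.6-fold lower number from compound 3 to compound 4 (0.42 log units; beyond the scatter), and an at least 2.6-fold lower number from compound 1 to compound 4 (0.42 log units; beyond the scatter). Going by these compounds, both steps start from a limit of the assay and not from a number, so their full size stays unknown: the limit of >= 100000 nM in this assay, at which 2 of the 4 values shown sit. The read numbers also separate among the aromatic groups, with a 3.0-fold higher number from compound 2 to compound 4 (0.48 log units; beyond the scatter), so the presence of an aromatic ring alone does not fix the number here, and thiophen-2-yl and 4-methylphenyl are not interchangeable.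

The step between compound 1 and compound 3 still cannot be read, with both ends at limits. Also open, on these data alone, is what an amine, a carboxylic acid or a longer alkyl chain on this aromatic carbon would give in this assay.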